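The compounds below may be only part of what the source reports. "The series", "measured", "known", "first", "only" and "open" are said of these compounds alone.

Measured compounds:
compound 1 `Cc1ccc(-c2nc(N)c3cc(Cc4ccccc4Cl)sc3n2)o1` — 26.1 nM
compound 2 `CCc1ccc(-c2nc(N)c3cc(Cc4ccccc4)sc3n2)o1` — 223 nM

In a functional assay on CHO-K1 cells for antagonist activity at adenosine receptor A1 (Homo sapiens), read by a beta-galactosidase reporter and cAMP accumulation, with stated times of 15 min and 6 h (a higher number here means a weaker inhibitor, a lower number a stronger inhibitor), compound 2 gives 223 nM, the higher of the two numbers shown, and its gap to compound 1 lies beyond the scatter. Compound 3 `Nc1nc(C2CCCO2)nc2sc(Cc3ccccc3)cc12` is not yet measured. It differs from compound 2 in one place: oxolan-2-yl in place of 5-ethylfuran-2-yl on an aromatic carbon. Going by the values given here, no measured pair shows the effect of this change, so the step of a 3.1-fold higher number from compound 2 to compound 3 (0.50 log units; beyond the scatter) is an expectation only; a modest rise, towards a weaker inhibitor, is expected. Compound 3 is therefore estimated at 700 nM, within 200 nM to 2500 nM.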

Compound 3, inhibition constant: 2950 nM
Compound 3: the middle estimate sits 4.2-fold (0.62 log units) below what was measured; measured number outside the range, above it.
By their numbers in this assay, from the lowest: compound 1; then compound 2; then compound 3.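

In this assay, replacing 5-ethylfuran-2-yl with oxolan-2-yl gives a 13-fold higher number from compound 2 to compound 3 (1.12 log units; beyond the scatter), so this position between two ring nitrogen atoms is sensitive to the group it carries. Both groups count one oxygen and one hydrogen-bond acceptor, so matching counts do not preserve the value; the entering ring is smaller and non-aromatic. Nothing measured here explains the size of this step. Ring size, aromaticity and the ethyl group all change together, leaving their separate contributions open. An unsubstituted furan-2-yl or a phenyl ring at this position would begin to separate them.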